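The source may report more compounds than this note shows. Statements on the series, on what has been measured and on what is new or still open speak of the compounds shown alone.

Measured so far:
Compound 1, `N/C(=N\O)c1ccc(C2=C(S(=O)(=O)c3ccc(F)cc3)CC3(CCCCC3)O2)cc1`, gives 92900 nM in an ADME assay on cells (Peritoneal macrophage, Mus musculus, strain Balb/c) for cytotoxicity, read by resazurin assay, with a stated time of 72 h; on this read-out higher numbers stand for lower toxicity in this test and lower numbers for higher toxicity in this test.
Compound 2, `CC1(Cc2ccc([N+](=O)[O-])cc2)CC(S(=O)(=O)c2ccc(F)cc2)=C(c2ccc(/C(N)=N/O)cc2)O1`, gives 97400 nM in this assay.

Among the measured compounds shown here, compound 2 holds the higher of these two numbers, but its only neighbour, compound 1, sits so close that the two values lie within the usual scatter, and no order between them can be read. Both compounds thus show only weak toxicity toward these mouse macrophage cells in this assay.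

Compound 3, `CC1(Cc2ccc(-c3ccccc3)cc2)CC(S(=O)(=O)c2ccc(F)cc2)=C(c2ccc(/C(N)=N/O)cc2)O1`, has not yet been tested. It differs from compound 2 in a single place: phenyl in place of nitro on an aromatic carbon. The nitro group leaves and a phenyl enters on that aromatic carbon, so the outer part of the side chain changes from 4-nitrophenyl to 4-phenylphenyl.

For the measured compounds named here, no measured pair shows this kind of change, so there is no step to lean on. With both measured values at nearly the same level, the expectation in this assay is a small downward move, toward somewhat higher toxicity, of a size that may well stay inside the scatter. Compound 3 is therefore expected to give about 60000 nM, with a likely range from 20000 nM to 150000 nM. This amounts to an expected step of a 1.6-fold lower number from compound 2 to compound 3 (0.21 log units; within the scatter).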

Compound 3, half-maximal cytotoxic concentration: 33900 nM
Beside the measured number, compound 3's estimate is 1.8-fold (0.25 log units) above it; low and high end bracket the measured number.
By their numbers in this assay, from the lowest: compound 3; then compounds 1 and 2 (each within the scatter of the next).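

Replacing nitro with phenyl on this aromatic carbon, para to a large group, gives a 2.9-fold lower number from compound 2 to compound 3 (0.46 log units; beyond the scatter) in this assay. Among the compounds shown here, this is the first step that lies beyond the usual scatter, so the outer end of the side chain is a place where a single change can move the read-out toward higher toxicity in this test, although the step is only modest. No supporting measurement accompanies this step, so the result cannot separate the effect of losing the nitro group from that of gaining the phenyl ring, and no explanation for it can be offered.

For the compounds shown here, with only this one pair, it remains open whether the read-out at this aromatic carbon follows a wider trend or simply reflects these two groups. An amine, a carboxylic acid or a methoxy group in the same place could show whether the number stays near that of compound 2 or moves toward that of compound 3, and whether the same swap behaves alike on other side chains is also unresolved.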